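This account rests on a few compounds, and the source may have more. Where it says the series, first, only, none or still open, it means among the compounds named here.

Compound 3 `C[C@H]([C@H](C(=O)Nc1cccc(CC2(C(=O)O)CC2)c1)c1ccc(Cl)cc1)C(F)(F)F` gives the smallest maximal response of the three measured in an assay on CHO cells for activation of Guanylate cyclase soluble subunit alpha-1 (Rattus norvegicus), read by luminescence and cGMP accumulation, with a stated time of 6 min (a higher number here means a larger maximal response, a lower number a smaller maximal response), at 4%. Compound 2 `Cc1c(CCC(=O)O)cccc1NC(=O)[C@H](c1ccc(Cl)cc1)C1CCCC1` sits nearest, in this assay at 19%, a gap beyond the scatter. Compound 1 `Cc1c(CCC(=O)O)cccc1NC(=O)[C@H](c1ccc(CN2N=C(c3ccccc3)OCC2=O)cc1)C1CCCC1` stands furthest away, in this assay at 110%. Compound 4 `C[C@H]([C@H](C(=O)Nc1cccc(CC2(C(=O)O)CC2)c1Cl)c1ccc(Cl)cc1)C(F)(F)F` differs from compound 3 in one place only: chloro in place of hydrogen on an aromatic carbon. Going by the values given here, no measured pair shows this change on its own, so nothing direct is known of its effect on the maximal response. In this assay the expected step is a number 3 percentage points higher from compound 3 to compound 4 (within the scatter), taken as none beyond the scatter. For compound 4 the estimated maximal response in this assay is 7%, with a range from 0% to 22%.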

Compound 4, largest response reached (reported as efficacy), in percent of the reference or control that the assay uses: 19%
Estimate against measurement, compound 4: 12 percentage points below; the measured number falls inside the stated range.
By their numbers in this assay, from the lowest: compound 3; then compounds 2 and 4 (each within the scatter of the next); then compound 1.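

Chloro in place of hydrogen on this aromatic carbon, ortho to the (1-carboxycyclopropyl)methyl group, gives in this assay a number 15 percentage points higher from compound 3 to compound 4 (beyond the scatter). Going by these compounds alone, this is the first direct reading of the change: the position takes a chlorine with a modest gain in maximal response, not a loss. Nothing at hand accounts for the step.

This single pair sets no pattern. As far as these compounds go, whether fluoro, methyl or methoxy at this position would give a similar step stays open, as does whether chloro would do so on the core of compound 1.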